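Methyl added to compound 2: expectation for compound 4

This account rests on a few compounds, and the source may have more. Where it says the series, first, only, none or still open, it means among the compounds named here.

In a functional assay on MDA-MB-231 cells (Homo sapiens) for antiproliferative activity, read by MTT assay, with a stated time of 72 h (on this read-out higher numbers stand for weaker inhibition and lower numbers for stronger inhibition), compound 2 (`O=C(CCc1cccc2c1B(O)OC2)Nc1cccc(Br)c1`) gives 720 nM and cannot be separated from compound 1 (`Cc1ccc(NC(=O)CCc2cccc3c2B(O)OC3)cc1`) at 1100 nM while compound 3 (`O=C(CCc1cccc2c1B(O)OC2)Nc1cccc(I)c1`) stands apart at 5300 nM on the weaker side. Compound 4 (`Cc1ccc(NC(=O)CCc2cccc3c2B(O)OC3)cc1Br`) differs from compound 2 by methyl in place of hydrogen on an aromatic carbon. Within the data shown here, no measured step is this change. The closest evidence is the exchange of aryl groups (a 1.5-fold lower number from compound 1 to compound 2 (0.18 log units; within the scatter)) and compound 4 carries both the methyl and the bromo. Against this, single aryl changes can matter here (a 7.4-fold higher number from compound 2 to compound 3 (0.87 log units; beyond the scatter)) and (a 4.8-fold higher number from compound 1 to compound 3 (0.68 log units; beyond the scatter)) though both steps are modest. In this assay a step within the scatter, without firm direction, is therefore expected (a 1.3-fold higher number from compound 2 to compound 4 (0.10 log units; within the scatter)). The estimate for compound 4 is 900 nM with 300 nM to 2600 nM as its expected range.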

Compound 4, half-maximal inhibitory concentration: 870 nM
Estimate against measurement, compound 4: 1.0-fold (0.01 log units) above, and the stated range covers the measured number.
By their numbers in this assay, from the lowest: compounds 2, 4 and 1 (each within the scatter of the next); then compound 3.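

In this assay, methyl on the aromatic carbon ortho to a bromo group and para to a large group leaves the number within the scatter (a 1.2-fold higher number from compound 2 to compound 4 (0.08 log units; within the scatter)). Bromo in place of hydrogen on compound 1 also stays within the scatter (a 1.3-fold lower number from compound 1 to compound 4 (0.10 log units; within the scatter)), so at this stage the methyl and the bromo can be present together without a separable change. No measurement shown gives a reason for either small step.

Going by these compounds, it remains open how this carbon responds to groups other than methyl, such as an amine or a carboxylic acid. On these data alone, replacing the bromo of compound 4 with iodo also remains open.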